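Turning one double bond from E to Z

This account rests on a few compounds, and the source may have more. Where it says the series, first, only, none or still open, it means among the compounds named here.

Compound 1 `COc1ccc(/C=C\c2ccc3ccccc3c2)cc1[N+](=O)[O-]`: > 20000 nM
Compound 2 `COc1c([N+](=O)[O-])cc(/C=C/c2ccc3ccccc3c2)cc1[N+](=O)[O-]`: > 5000 nM

Both compounds were tested in a functional assay on P388 cells (Mus musculus) for inhibition; on this read-out lower numbers stand for stronger inhibition and higher numbers for weaker inhibition. In that test, compound 2 gives > 5000 nM, which is a limit and not a number. Compound 1 gives > 20000 nM, which is also a limit and not a number. Neither compound therefore has an exact potency on record.

Compound 3 `COc1c([N+](=O)[O-])cc(/C=C\c2ccc3ccccc3c2)cc1[N+](=O)[O-]` has yet to be measured. Its relation to compound 2 is simple: the two compounds have the same atoms and bonds and differ only in configuration as drawn: 1 of 1 stereo elements differ; a double bond is drawn E in compound 2 and Z in compound 3. Going by the values given here, no measured step between two compounds shows what such a change does in this assay. The only anchor is the limit of compound 2, > 5000 nM, so weak inhibition is expected to persist. The expected change is small, and the estimated step is a step that the limit leaves unreadable from compound 2 to compound 3. For compound 3 the expected value is 8000 nM, with an estimated range from 1500 nM to 40000 nM.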

Compound 3, half-maximal inhibitory concentration: > 5000 nM
Compound 3: only a limit was reported; the forecaster's own chance of this, stated with the estimate: 60%; the middle value lies beyond the limit too.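

In this assay compound 3 gives > 5000 nM, which is a limit and not a number. Going by these compounds alone, compound 1 and compound 2 also carry limits, and no step from either of them to compound 3 can be read. The compounds shown leave open whether turning the double bond from E to Z, or adding the nitro group, changes inhibition at all.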